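From Methoxy to Fluoro on One Aromatic Carbon

This account rests on a few compounds, and the source may have more. Where it says the series, first, only, none or still open, it means among the compounds named here.

Of the compounds shown here, three have been measured in a functional assay on HL-60 cells (Homo sapiens) for cytotoxicity, read by MTT assay, with a stated time of 72 h (a higher number here means a weaker inhibitor, a lower number a stronger inhibitor), so far. Compound 1 (`O=S(=O)(c1ccc(F)cc1)c1nc2ccccc2nc1N1CCCC1`) reads 12800 nM and compound 2 (`Cc1ccc(S(=O)(=O)c2nc3ccccc3nc2N2CCCC(O)C2)cc1`) reads 6080 nM while compound 3 (`COc1ccc(S(=O)(=O)c2nc3ccccc3nc2N2CCCC(O)C2)cc1`) reads 3050 nM on the same scale. Compound 3 stands level with compound 2, within the scatter, and its number is lower than that of compound 1 by more than the scatter.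

The next compound, compound 4 (`O=S(=O)(c1ccc(F)cc1)c1nc2ccccc2nc1N1CCCC(O)C1`), keeps everything in compound 3 except one group: fluoro in place of methoxy on an aromatic carbon, para to a large group (fluoro in place of methoxy on an aromatic carbon). Going by the values given here, only one measured step touches this same place, methoxy in place of methyl (a 2.0-fold lower number from compound 2 to compound 3 (0.30 log units; within the scatter)). Compound 1 also carries the 4-fluorophenyl group, yet it differs elsewhere too, and that leaves no clean comparison. Its value (12800 nM) offers only a weak hint toward a higher number for compound 4.

In this assay the expected step is small and not beyond the scatter (a 1.5-fold higher number from compound 3 to compound 4 (0.17 log units; within the scatter)). For compound 4 the estimated value is 4500 nM with a wide expected range (1800 nM to 11000 nM).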

Compound 4, half-maximal inhibitory concentration: 2620 nM
Beside the measured number, compound 4's estimate is 1.7-fold (0.23 log units) above it; low and high end bracket the measured number.
By their numbers in this assay, from the lowest: compounds 4, 3 and 2 (each within the scatter of the next, the first and the last beyond it); then compound 1.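

In this assay, swapping methoxy for fluoro on this aromatic carbon leaves the reading level (a 1.2-fold lower number from compound 3 to compound 4 (0.07 log units; within the scatter)), so a single fluorine atom serves here as well as the two heavy atoms of methoxy. Comparing the methyl and fluoro compounds gives the only step at this position that passes the scatter, and it is modest (a 2.3-fold lower number from compound 2 to compound 4 (0.37 log units; beyond the scatter)), while compound 3 stays within the scatter of both. With the 4-fluorophenyl group held fixed, a change elsewhere on the molecule, 3-hydroxypiperidin-1-yl in place of pyrrolidin-1-yl, also gives a modest step beyond the scatter (a 4.9-fold lower number from compound 1 to compound 4 (0.69 log units; beyond the scatter)), but nothing available explains any of these steps.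

On these data alone, it remains open whether a chlorine atom, a nitrile or a carboxylic acid on this same aromatic carbon would keep the reading level or move it beyond the scatter. Also open, as far as these compounds go, is how an amine or a longer chain in place of the hydroxy group on the piperidine ring would read.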